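Replacing a chain on the carbonyl of compound 1

The source may hold more compounds than are shown below. What is called first, only, known or untested is meant among the compounds shown, and "the series" means these compounds.

Compound 1, `CO[C@H](C(=O)NS(=O)(=O)OC[C@H]1O[C@@H](n2cnc3c(N)nc(Cl)nc32)[C@H](O)[C@@H]1O)[C@H](OC)C(C)C`, was tested in a functional assay on MDA-MB-231 cells (Homo sapiens) for antiproliferative activity, read by sulforhodamine B assay, with a stated time of 72 h; a lower number here means a stronger inhibitor, a higher number a weaker inhibitor. In this assay compound 1 gives only a limit, > 20000 nM, not a number. For the measured compounds named here, the only thing known of compound 1 there is therefore (the limit of > 20000 nM in this assay, at which 1 of the 2 values shown sits). Going by the values given here, compound 2, `Nc1ncnc2c1ncn2[C@@H]1O[C@H](COS(=O)(=O)NC(=O)[C@@H](O)[C@H](O)C2CC2)[C@@H](O)[C@@H]1O`, is the other measured compound and shares no single-point step with compound 1. In this assay compound 2 gives 17800 nM, which is also a weak result. Compound 3, `CC(C)C[C@H](Cl)C(=O)NS(=O)(=O)OC[C@H]1O[C@@H](n2cnc3c(N)nc(Cl)nc32)[C@H](O)[C@@H]1O`, has not yet been measured. It differs from compound 1 in one place: a group of 6 heavy atoms (5 carbon, 1 chlorine; no ring) in place of a group of 9 heavy atoms (7 carbon, 2 oxygen; no ring), on a carbonyl carbon. Among the compounds with values here, no measured step shows how a change on this carbonyl carbon moves activity in this assay, so the expectation can rest only on the two weak values seen so far. The estimated step of an at least 1.1-fold lower number from compound 1 to compound 3 (0.04 log units; that floor lies within the scatter) is expected to be small, with no direction that goes beyond the usual scatter. Compound 3 is therefore expected to give about 18000 nM, within a range of 5000 nM to 60000 nM, and it may well be reported only as a limit again.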

Compound 3, half-maximal inhibitory concentration: 7750 nM
For compound 3 the middle estimate is 2.3-fold (0.37 log units) above the measured one, within the range that was stated.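

For the compounds shown here, on this carbonyl carbon, the chain does affect activity: in this assay, replacing the group of 9 heavy atoms (7 carbon, 2 oxygen; no ring) with the group of 6 heavy atoms (5 carbon, 1 chlorine; no ring) gives an at least 2.5-fold lower number from compound 1 to compound 3 (0.41 log units; beyond the scatter), the first measured step at this place and one that lies beyond the scatter. The size of this step is only a floor, because compound 1 gives a limit and not a number: the limit of > 20000 nM in this assay, at which 1 of the 3 values shown sits. Even after the change, compound 3, at 7750 nM, remains a weak inhibitor in this assay.

This one step alters the heavy-atom count, removes both oxygens with their 2 hydrogen-bond acceptors and brings in chlorine all at once, and it cannot show which of these differences matters. The compounds shown leave open whether a plain alkyl chain without chlorine, a fluorine or bromine in place of the chlorine, or an amine on this chain would give a number as low as that of compound 3 or a lower one.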